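The source may report more compounds than this note shows. Statements on the series, on what has been measured and on what is new or still open speak of the compounds shown alone.

Compound 1 `O=C1/C(=C/c2ccccc2F)CN(S(=O)(=O)c2ccccc2)C/C1=C\c1ccccc1F` gives 5700 nM.
Compound 2 `O=C1/C(=C/c2cccc(F)c2)CN(S(=O)(=O)c2ccccc2)C/C1=C\c1cccc(F)c1` gives 12900 nM.
Compound 3 `Cc1ccc(S(=O)(=O)N2C/C(=C\c3cccc(F)c3)C(=O)/C(=C/c3cccc(F)c3)C2)cc1` gives 18100 nM.

All three were measured in a functional assay on SMMC-7721 cells (Homo sapiens) for cytotoxicity, read by MTT assay, with a stated time of 24 h; a lower number here means a stronger inhibitor, a higher number a weaker inhibitor. Compound 3 carries the highest of the three numbers, although its gap to compound 2 lies within the scatter, while its gap to compound 1 lies beyond it. For the measured compounds named here, the only single-point change measured so far, a methyl in place of hydrogen on an aromatic carbon, gave a 1.4-fold higher number from compound 2 to compound 3 (0.15 log units; within the scatter). Compound 4 `O=C1/C(=C/c2cccc(F)c2)CN(S(=O)(=O)c2ccc(O[N+](=O)[O-])cc2)C/C1=C\c1cccc(F)c1` differs from compound 3 by nitrooxy in place of methyl on an aromatic carbon. Going by the values given here, no measured step exchanges a methyl for a nitrooxy group, so the only guide is that one measured step, which stayed within the scatter. The step from compound 3 to compound 4 is therefore expected to be small, a 1.2-fold lower number from compound 3 to compound 4 (0.08 log units; within the scatter), with no firm direction. Compound 4 is estimated at 15000 nM, within 6000 nM to 40000 nM.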

Compound 4, half-maximal inhibitory concentration: 15300 nM
Estimate against measurement, compound 4: 1.0-fold (0.01 log units) below; the range from low to high includes it.
By their numbers in this assay, from the lowest: compound 1; then compounds 2, 4 and 3 (each within the scatter of the next).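

Nitrooxy is a larger group than methyl by heavy-atom count, yet at this position, para to a large group, the exchange stays within the scatter (a 1.2-fold lower number from compound 3 to compound 4 (0.07 log units; within the scatter)). Set against plain hydrogen, nitrooxy also stays within the scatter (a 1.2-fold higher number from compound 2 to compound 4 (0.07 log units; within the scatter)). Hydrogen, methyl and nitrooxy therefore give numbers that cannot be told apart here, which the single methyl step could not show. No measurement at hand accounts for this.

On these data alone, whether an amine or a carboxylic acid at this position would give a step beyond the scatter remains open. So does whether nitrooxy behaves the same way on the core of compound 1.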